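The compounds below may be only part of what the source reports. "The series", "measured", "known", "first", "only" and "open" are said of these compounds alone.

Compound 1 `C/N=C(\S)NCCCCCn1nc(-c2ccccc2)ccc1=O` stands highest of the three compounds measured in a functional assay on the whole organism with Rattus norvegicus as the target, at a dose of 100 mg/kg (on this read-out lower numbers stand for less inhibition and higher numbers for more inhibition at the one dose given (going by the name of the read-out)), giving 68.9%. Compound 2 `CC/N=C(/NC#N)NCCCCCCn1nc(-c2ccccc2)ccc1=O` gives 29.1% in this assay, and compound 3 `C/N=C(\S)NCCCCCn1nc(C)ccc1=O` gives 3.2%. Both measured steps are large falls: a number 65.7 percentage points lower from compound 1 to compound 3 (beyond the scatter), and a number 39.8 percentage points lower from compound 1 to compound 2 (beyond the scatter). Compound 4 `C/N=C(\NC#N)NCCCCn1nc(-c2ccccc2)ccc1=O` differs from compound 1 by a group of 7 heavy atoms (3 carbon, 4 nitrogen; no ring) in place of a group of 6 heavy atoms (3 carbon, 2 nitrogen, 1 sulfur; no ring), on a saturated chain carbon, four bonds along the chain from an aromatic nitrogen. The step from compound 1 to compound 2 is the comparable one: there too a cyanoguanidine enters in place of an isothiourea on the chain, and the inhibition fell well beyond the scatter. A fall of similar size is therefore expected for compound 4, a number 38.9 percentage points lower from compound 1 to compound 4 (beyond the scatter). Compound 4 is estimated at 30% in this assay, with a range of 10% to 55%.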

Compound 4, a percentage reported as inhibition, in the whole organism at one dose (the size of the read-out at that dose, not a potency): 79%
Compound 4: middle estimate off by 49 percentage points, on the low side; measured number above the stated range.
By their numbers in this assay, from the lowest: compound 3; then compound 2; then compound 1; then compound 4.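

The step of a number 10.1 percentage points higher from compound 1 to compound 4 (beyond the scatter) in this assay shows that the group of 7 heavy atoms (3 carbon, 4 nitrogen; no ring), four bonds along the chain from an aromatic nitrogen, can keep inhibition at the level of compound 1 or slightly above it. The larger fall, a number 39.8 percentage points lower from compound 1 to compound 2 (beyond the scatter), therefore cannot be read as a general result of replacing the sulfur-bearing group, and compound 2 and compound 4 point in opposite directions. No measurement here bears on the reason for this difference.

Still open, going by these compounds, is the effect of chain length alone with the end group held fixed. Also open, on these data alone, is how an amine at the chain end would compare.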